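Replacing the Phenyl with a Hydroxy on the Fused Core

The compounds below may be only part of what the source reports. "The series", "measured", "known", "first", "only" and "open" are said of these compounds alone.

Compound 2 `c1ccc(-c2cccc3c2C2CNCC3C2)cc1` carries a phenyl on the aromatic ring of its fused core. Going by the values given here, in an assay on HEK293 cells for binding affinity to Neuronal acetylcholine receptor; alpha4/beta2 (Homo sapiens) (a lower number here means a stronger inhibitor, a higher number a weaker inhibitor), compound 2 gives 1600 nM, the highest of the three numbers measured so far. Compound 1 `Fc1cccc2c1C1CNCC2C1` differs from compound 2 only in carrying a fluoro in place of that phenyl; in this assay compound 1 gives 200 nM. Compound 3 `Nc1ccc2c(c1)C1CNCC2C1`, an amino-bearing analogue of the same core, gives 100 nM. Among the compounds with values here, the one step measured between these compounds runs from the fluoro to the phenyl: an 8.0-fold higher number from compound 1 to compound 2 (0.90 log units; beyond the scatter). Compound 4 `Oc1cccc2c1C1CNCC2C1` has not yet been measured; it differs from compound 2 in one place: hydroxy in place of phenyl on an aromatic carbon. The step that bears on it is the measured one, where exchanging fluoro for phenyl raised the number well beyond the scatter. Removing that phenyl again and putting a hydroxy in its place is expected to move the number back down, by roughly the size of that measured step. For compound 4 the expected step is an 11-fold lower number from compound 2 to compound 4 (1.03 log units; beyond the scatter). Compound 4 is therefore estimated at 150 nM in this assay, within a range from 50 nM to 500 nM.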

Compound 4, inhibition constant: 1700 nM
For compound 4 the middle estimate is 11-fold (1.05 log units) below the measured one; measured number outside the range, above it.
By their numbers in this assay, from the lowest: compounds 3 and 1 (each within the scatter of the next); then compounds 2 and 4 (each within the scatter of the next).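

In this assay, a hydroxy of 1 heavy atom and a phenyl of 6 heavy atoms on this aromatic carbon cannot be told apart, with a 1.1-fold higher number from compound 2 to compound 4 (0.03 log units; within the scatter), although the hydroxy also brings 1 hydrogen-bond donor and 1 hydrogen-bond acceptor that the phenyl lacks. Removing the phenyl's carbon ring therefore does not by itself restore the number of compound 1: an 8.5-fold higher number from compound 1 to compound 4 (0.93 log units; beyond the scatter), so among the three groups placed here, the fluoro alone stands apart from the other two, and the earlier step between fluoro and phenyl turns out not to be a matter of the phenyl alone. No measurement at hand explains why the fluoro differs from both of the other groups at this position.

As far as these compounds go, what remains open is whether a methoxy, a methyl or a chlorine on this same carbon would fall with the fluoro or with the phenyl and the hydroxy. The compounds shown also leave open whether the gap between fluoro and hydroxy holds in any assay other than this assay.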